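Amide aryl swap in an antiproliferative series: compound 4

A few compounds are considered here, and "the series" means these few. Any claim that something is new, unique, unknown or untested is made for them only; others in the source may bear on it.

Measured so far in a functional assay on A375P cells (Homo sapiens) for antiproliferative activity, read by MTT assay, with a stated time of 48 h; on this read-out lower numbers stand for stronger inhibition and higher numbers for weaker inhibition:
Compound 1 `Cc1ccc(C(=O)Nc2cccc(-c3ccnc4c(N)cccc34)c2)cc1C` gives > 20000 nM, a limit of the assay.
Compound 2 `Nc1cccc2c(-c3cccc(NC(=O)c4ccc(C(F)(F)F)cc4C(F)(F)F)c3)ccnc12` gives > 20000 nM, a limit of the assay.
Compound 3 `CC(=O)Nc1cccc2c(-c3cccc(NC(=O)c4ccc(C)c(C)c4)c3)ccnc12` gives > 20000 nM, a limit of the assay.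

Compound 3 thus stands at the limit of > 20000 nM in this assay, at which 3 of the 3 values shown sit, with no number that would place it relative to the others. Going by the values given here, the one single-point step, a step that the two limits leave unreadable from compound 1 to compound 3, is not readable for size. Compound 4 `CC(=O)Nc1cccc2c(-c3cccc(NC(=O)c4cc5ccccc5s4)c3)ccnc12` carries the change (1-benzothiophen-2-yl in place of 3,4-dimethylphenyl on a carbonyl carbon). Among the compounds with values here, no measured step touches the amide aryl group, so no direction beyond the scatter can be taken from the data. For compound 4 the expected value in this assay is 15000 nM, with a range of 3000 nM to 40000 nM, and most likely again only a limit.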

Compound 4, half-maximal inhibitory concentration: 9100 nM
Estimate against measurement, compound 4: 1.6-fold (0.22 log units) above; low and high end bracket the measured number.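

In this assay, 1-benzothiophen-2-yl in place of 3,4-dimethylphenyl on a carbonyl carbon gives an at least 2.1-fold lower number from compound 3 to compound 4 (0.34 log units; beyond the scatter). This shows that a change at this position alone can bring the series off the assay limit, and compound 4 is the only compound shown with a measured number: the limit of > 20000 nM in this assay, at which 3 of the 4 values shown sit.

On these data alone, the step from compound 1 to compound 3 cannot be read, and 1-benzothiophen-2-yl appears only with the acetyl group, so the part played by the acetyl stays open. As far as these compounds go, it also remains open whether the sulfur matters, which a naphthyl or indolyl group on the same carbonyl carbon could address.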